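A Furan in Place of a Hydroxy-Methoxyphenyl Arm

The source may hold more compounds than are shown below. What is called first, only, known or untested is meant among the compounds shown, and "the series" means these compounds.

Compound 1 `CC(C)Cc1ccc2c(NCCCNCc3ccco3)ccnc2c1`: 16000 nM
Compound 2 `COc1ccc(Oc2ccc3c(NCCCNCc4cccc(OC)c4O)ccnc3c2)cc1`: 5500 nM

Among the measured compounds shown here, in an ADME assay on HepG2 cells (Homo sapiens) for cytotoxicity, read by luminescence, CellTiter-Glo and ATP content, with a stated time of 72 h (on this read-out lower numbers stand for an effect already at smaller amounts and higher numbers for an effect only at larger amounts of compound), compound 2 gives the lower of the two numbers, and compound 1, the only other measured compound, gives a number beyond the scatter above it. Compound 3 `COc1ccc(Oc2ccc3c(NCCCNCc4ccco4)ccnc3c2)cc1` is not yet measured. It differs from compound 2 in one place: furan-2-yl in place of 2-hydroxy-3-methoxyphenyl on a saturated chain carbon bound to an amine nitrogen. Compound 1 carries the same furan arm, though on a different core, and its value in this assay lies above that of compound 2, so the furan is here associated with the higher number. For the measured compounds named here, no step between measured compounds isolates this change, so the expected step from compound 2 to compound 3 is only estimated, as a modest rise a 1.6-fold higher number from compound 2 to compound 3 (0.21 log units; within the scatter) in this assay. Compound 3 is therefore expected to give about 9000 nM, within a range from 4000 nM to 20000 nM.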

Compound 3, half-maximal effective concentration: 5300 nM
The estimate for compound 3 lay 1.7-fold (0.23 log units) above the measured number, and the stated range covers the measured number.
By their numbers in this assay, from the lowest: compounds 3 and 2 (each within the scatter of the next); then compound 1.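

In this assay furan-2-yl in place of 2-hydroxy-3-methoxyphenyl on a saturated chain carbon bound to an amine nitrogen gives a 1.0-fold lower number from compound 2 to compound 3 (0.02 log units; within the scatter) and so leaves the number within the scatter, although the arm loses its hydrogen-bond donor and four heavy atoms. With the furan arm held constant, 4-methoxyphenoxy in place of isobutyl on an aromatic carbon gives a 3.0-fold lower number from compound 1 to compound 3 (0.48 log units; beyond the scatter) and so, among these compounds, the change beyond the scatter goes with the group on the aromatic carbon and not with the arm. No measurement shown offers a reason for either result.

On these data alone, it remains open whether the 2-hydroxy-3-methoxyphenyl arm would match the furan on the core of compound 1 as well. Also open, as far as these compounds go, is how an arm carrying an amine or a carboxylic acid, or a longer chain, would read.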